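Working notes: methoxy to hydroxy in a ketone series

The compounds below may be only part of what the source reports. "The series", "measured", "known", "first", "only" and "open" are said of these compounds alone.

Measured compounds:
compound 1 `CCc1oc2ccc(O)cc2c1C(=O)c1ccc(OC)cc1` — "not determined" (no result reported)
compound 2 `CCc1cc2c(C(=O)c3ccc(O)cc3)c(O)ccc2o1` — "not determined" (no result reported)
compound 3 `CCc1oc2ccc(OC)cc2c1C(=O)c1cc(Br)c(O)c(Br)c1` — 42 nM

In an assay for inhibition of solute carrier family 22 member 12 (Homo sapiens), read by scintillation counting, with a stated time of 60 min (a lower number here means a stronger inhibitor, a higher number a weaker inhibitor), compound 3 gives 42 nM. For the measured compounds named here, compound 3 stands alone on the numbers: in this assay compound 1 gives "not determined" (no result reported) and compound 2 gives "not determined" (no result reported), so there is no second value to set compound 3 against, and no step between measured compounds can be drawn from the series as it stands.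

Compound 4 `CCc1oc2ccc(O)cc2c1C(=O)c1cc(Br)c(O)c(Br)c1` differs from compound 3 in one place: hydrogen in place of methyl on an oxygen on an aromatic ring, the same difference read one bond further out being methoxy to hydroxy. Going by the values given here, no measured pair shows what this change does in this assay, so what is expected for compound 4 rests on compound 3 alone and on the small size of the change. The expected step from compound 3 to compound 4 is a 1.4-fold higher number from compound 3 to compound 4 (0.15 log units; within the scatter), which is meant as small and not clearly beyond the scatter in either direction. For compound 4 the estimate in this assay is 60 nM, within a range from 15 nM to 250 nM.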

Compound 4, half-maximal inhibitory concentration: 189 nM
For compound 4 the middle estimate is 3.2-fold (0.50 log units) below the measured one; the measured number falls inside the stated range.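

For the compounds shown here, the methoxy to hydroxy change on this oxygen now has a reading in this assay, with a 4.5-fold higher number from compound 3 to compound 4 (0.65 log units; beyond the scatter) as the first step, where the earlier compounds offered only a single number. The position is therefore not indifferent to this change: with the rest of the structure held the same, hydrogen in place of methyl costs a modest but real amount, beyond the scatter. Nothing shown explains this step.

This is one pair at one place, so it sets no pattern for the series. Going by these compounds, whether a longer chain on this oxygen, such as ethoxy, or an amine in place of the hydroxy would give a lower or a higher number remains open, as does the effect of the same change elsewhere on the shared core.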